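The source may hold more compounds than are shown below. What is called first, only, known or untested is meant among the compounds shown, and "the series" means these compounds.

Compound 1 `CN1CCC(NC(=O)Nc2cccc3[nH]ncc23)c2ccccc21`: 215 nM in a functional assay for antagonist activity at transient receptor potential cation channel subfamily V member 1 (Homo sapiens), read by calcium flux; a higher number here means a weaker inhibitor, a lower number a stronger inhibitor. Compound 2 `CN1CCC(NC(=O)Nc2cccc3[nH]ncc23)c2ccc(C(C)(C)C)cc21`: 115 nM in this assay.

On these two numbers compound 1 stands highest, with compound 2 nearest at a 1.9-fold lower number from compound 1 to compound 2 (0.27 log units; within the scatter). Compound 3 `COc1ccc2c(c1)C(NC(=O)Nc1cccc3[nH]ncc13)CCN2C` differs from compound 1 by methoxy in place of hydrogen on an aromatic carbon. Within the data shown here, the only measured step that bears on a substituent entering this ring is the one from compound 1 to compound 2, which stayed within the scatter. The step from compound 1 to compound 3 in this assay is therefore expected to be a 1.1-fold lower number from compound 1 to compound 3 (0.03 log units; within the scatter), no change beyond the scatter. Compound 3 is estimated at 200 nM, with a range of 80 nM to 500 nM.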

Compound 3, half-maximal inhibitory concentration: 1380 nM
Beside the measured number, compound 3's estimate is 6.9-fold (0.84 log units) below it, and the stated range ends below it.
By their numbers in this assay, from the lowest: compounds 2 and 1 (each within the scatter of the next); then compound 3.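

Methoxy in place of hydrogen on this aromatic carbon gives a weaker inhibitor in this assay, with a 6.4-fold higher number from compound 1 to compound 3 (0.81 log units; beyond the scatter). Until now the only step on the aromatic ring, a 1.9-fold lower number from compound 1 to compound 2 (0.27 log units; within the scatter), had shown no change beyond the scatter, so this is the first sign that a substituent on this ring can cost activity. No measurement shown here accounts for the loss.

Going by these compounds, it remains open whether the loss belongs to methoxy itself or to any group entering at this carbon. Fluorine or a hydroxyl group on the same carbon would help separate these two readings.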